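The compounds below may be only part of what the source reports. "The series", "measured", "known", "first", "only" and "open" are said of these compounds alone.

Compound 1 `Cc1c(C(=O)N/N=C\c2ccccc2C(F)(F)F)oc2cccc(O)c12` gives 26200 nM in a functional assay on PC-3 cells (Homo sapiens) for inhibition; a higher number here means a weaker inhibitor, a lower number a stronger inhibitor.
Compound 2 `Cc1ccc(O)c(/C=N\NC(=O)c2oc3cccc(O)c3c2C)c1` gives 7350 nM.
Compound 3 `Cc1c(C(=O)N/N=C\c2cc([N+](=O)[O-])ccc2O)oc2cccc(O)c12` gives 17100 nM.

Among these three, compound 2 holds the lowest number, and each other compound lies beyond the scatter from it. Going by the values given here, the one single-point change measured so far, nitro in place of methyl on an aromatic carbon, gives a 2.3-fold higher number from compound 2 to compound 3 (0.37 log units; beyond the scatter). Compound 4 `Cc1c(C(=O)N/N=C\c2cccc(Br)c2O)oc2cccc(O)c12` differs from compound 2 by 3-bromo-2-hydroxyphenyl in place of 2-hydroxy-5-methylphenyl on a carbon with a double bond to nitrogen. Among the compounds with values here, only the step from compound 2 to compound 3 bears on this, and only loosely, since bromine and nitro are different groups at different places. A modest rise of similar size is expected, so the step from compound 2 to compound 4 is estimated at a 1.5-fold higher number from compound 2 to compound 4 (0.18 log units; within the scatter). Compound 4 is therefore expected to give about 11000 nM, with a range from 4500 nM to 27000 nM.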

Compound 4, half-maximal inhibitory concentration: 16600 nM
Compound 4: the middle estimate sits 1.5-fold (0.18 log units) below what was measured; measured number inside the range.
By their numbers in this assay, from the lowest: compound 2; then compounds 4, 3 and 1 (each within the scatter of the next).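

Replacing the aromatic group on the carbon with a double bond to nitrogen gives a 2.3-fold higher number from compound 2 to compound 4 (0.35 log units; beyond the scatter) in this assay, even though the two groups match in their counts of heavy atoms, hydrogen-bond donors and acceptors. This is a second change at this position that raises the number from compound 2, so the rise is not confined to the nitro replacement. Bromine enters while methyl leaves, and no measured property here explains the rise.

As far as these compounds go, it remains open whether an amine or a carboxylic acid on this aromatic ring would lower the number. Compound 2 and compound 4 also cannot separate the effect of adding bromine from that of removing methyl.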